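Moving the Methyl Group on the Benzyl Substituent

This account rests on a few compounds, and the source may have more. Where it says the series, first, only, none or still open, it means among the compounds named here.

Compound 2 `O=C1/C(=C\c2ccccc2)c2c(ncn2COCc2ccccc2)CCN1Cc1ccc(F)cc1` was tested in a functional assay on HCT-116 cells (Homo sapiens) for inhibition, read by MTT assay, with a stated time of 72 h (on this read-out lower numbers stand for stronger inhibition and higher numbers for weaker inhibition), where compound 2 gives 11200 nM. Among the three measured compounds it holds the second highest number. Compound 1 `Cc1ccc(CN2CCc3ncn(COCc4ccccc4)c3/C(=C/c3ccccc3)C2=O)cc1` gives 7940 nM, which is a 1.4-fold higher number from compound 1 to compound 2 (0.15 log units; within the scatter), while compound 3 `COc1ccc(CN2CCc3ncn(COCc4ccccc4)c3/C(=C/c3ccccc3)C2=O)cc1` gives 31100 nM, which is a 2.8-fold higher number from compound 2 to compound 3 (0.44 log units; beyond the scatter).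

Compound 4 `Cc1ccccc1CN1CCc2ncn(COCc3ccccc3)c2/C(=C/c2ccccc2)C1=O` has not yet been measured. It differs from compound 2 in one place: 2-methylphenyl in place of 4-fluorophenyl on a saturated chain carbon bound to an amide-type nitrogen in a ring. Two things change at once here. The exchange of fluoro for methyl has a measured counterpart in a 1.4-fold higher number from compound 1 to compound 2 (0.15 log units; within the scatter), a step that stayed within the scatter. Going by the values given here, the change from a 4-fluorophenyl to a 2-methylphenyl also shifts where the substituent sits on the ring, and for that part no measured pair gives guidance. Resting on the one known step alone, compound 4 is expected to stay close to compound 2, a step of a 1.2-fold lower number from compound 2 to compound 4 (0.07 log units; within the scatter), meaning nothing beyond the scatter. The estimate for compound 4 is therefore 9500 nM, with a range from 4000 nM to 25000 nM.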

Compound 4, half-maximal inhibitory concentration: 24700 nM
Beside the measured number, compound 4's estimate is 2.6-fold (0.41 log units) below it; low and high end bracket the measured number.
By their numbers in this assay, from the lowest: compounds 1 and 2 (each within the scatter of the next); then compounds 4 and 3 (each within the scatter of the next).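

Changing 4-methylphenyl to 2-methylphenyl keeps the same atoms and alters only where the methyl sits on the ring, yet it gives a 3.1-fold higher number from compound 1 to compound 4 (0.49 log units; beyond the scatter) and so shows that the place of the substituent counts at this position, not only its kind. The change from 4-fluorophenyl gives a 2.2-fold higher number from compound 2 to compound 4 (0.34 log units; beyond the scatter) as well, even though the 4-fluorophenyl and 4-methylphenyl groups stayed within the scatter of each other. Against 4-methoxyphenyl the result is a 1.3-fold lower number from compound 3 to compound 4 (0.10 log units; within the scatter) and stays within the scatter, so moving the methyl leaves the number level with that of the methoxy group.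

Still open, as far as these compounds go, is how an amine, a carboxylic acid or a longer chain on this benzyl ring would behave. Nothing measured here explains why the place of the methyl matters.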